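Fluoro on the phenylsulfanyl group of compound 3

The source may hold more compounds than are shown below. What is called first, only, known or untested is meant among the compounds shown, and "the series" means these compounds.

Three compounds sharing one core have numbers in a functional assay on MCF7 cells (Homo sapiens) for antiproliferative activity, read by sulforhodamine B assay, with a stated time of 3 days; a higher number here means a weaker inhibitor, a lower number a stronger inhibitor. Compound 1 `Clc1ccc(Sc2ncnc3ncn(C4COc5ccccc5CO4)c23)c(Cl)c1` gives 8400 nM, compound 2 `C=CCOc1ncnc2ncn(C3COc4ccccc4CO3)c12` gives 20900 nM, and compound 3 `c1ccc(Sc2ncnc3ncn(C4COc5ccccc5CO4)c23)cc1` gives 15600 nM. Compound 3 is not separated from either of the others, as a 1.9-fold higher number from compound 1 to compound 3 (0.27 log units; within the scatter) and a 1.3-fold lower number from compound 2 to compound 3 (0.13 log units; within the scatter) show. Only the remaining pair stands apart, with a 2.5-fold higher number from compound 1 to compound 2 (0.40 log units; beyond the scatter).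

The next compound is compound 4 `Fc1ccc(Sc2ncnc3ncn(C4COc5ccccc5CO4)c23)cc1`. It carries fluoro in place of hydrogen on an aromatic carbon, para to a large group, so that phenylsulfanyl becomes (4-fluorophenyl)sulfanyl (fluoro in place of hydrogen on an aromatic carbon).

For the measured compounds named here, no measured step makes this exact change. The nearest evidence is the pair that differs only on the aromatic group held by the sulfur: compound 1, with 2,4-dichlorophenyl, and compound 3, with phenyl, at a 1.9-fold higher number from compound 1 to compound 3 (0.27 log units; within the scatter). Even that larger change stays small. The step involving compound 2, a 1.3-fold lower number from compound 2 to compound 3 (0.13 log units; within the scatter), replaces the whole group on the core and bears on this change only loosely. A single fluoro is therefore expected to move the number little, if at all, and any shift would most likely lean towards compound 1. The expected step is a 1.2-fold lower number from compound 3 to compound 4 (0.08 log units; within the scatter), with nothing beyond the scatter anticipated. For compound 4 the estimate in this assay is 13000 nM, with an expected range of 7500 nM to 22000 nM.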

Compound 4, half-maximal inhibitory concentration: 14100 nM
Compound 4: middle estimate off by 1.1-fold (0.04 log units), on the low side; the measured number falls inside the stated range.
By their numbers in this assay, from the lowest: compounds 1, 4, 3 and 2 (each within the scatter of the next, the first and the last beyond it).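

Fluoro in place of hydrogen, para to a large group, is the only single-atom change in this set, and in this assay it gives a 1.1-fold lower number from compound 3 to compound 4 (0.04 log units; within the scatter) and so does not separate the two compounds. The wider change on the sulfur also stays unresolved, with a 1.7-fold higher number from compound 1 to compound 4 (0.22 log units; within the scatter) on going from 2,4-dichlorophenyl to 4-fluorophenyl and a 1.5-fold lower number from compound 2 to compound 4 (0.17 log units; within the scatter) on replacing allyloxy with (4-fluorophenyl)sulfanyl on the core. Compound 4 therefore sits within the scatter of all three earlier compounds and does not add a second separated pair to the one already printed, and nothing available bears on why this fluoro step is so small.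

Still open, on these data alone, is whether a group of another kind on the same aromatic carbon, such as an amine or a carboxylic acid, would move the number beyond the scatter. Also open, as far as these compounds go, is whether a longer chain in place of allyloxy on the core would separate from compound 2 or would stay as close to the sulfur-linked compounds as allyloxy does here.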